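The source may hold more compounds than are shown below. What is called first, only, known or untested is meant among the compounds shown, and "the series" means these compounds.

Measured so far:
Compound 1, `C=C(C)C(O)Cc1c(O)cc(CCc2ccccc2)c(C(=O)OC)c1O`, gives 36600 nM.
Compound 2, `CC1=CCc2c(O)cc(CCc3ccccc3)cc2OC1`, gives > 40000 nM.

Both numbers come from a functional assay on A549 cells (Homo sapiens) for cytotoxicity, read by MTT assay, with a stated time of 48 h; a higher number here means a weaker inhibitor, a lower number a stronger inhibitor. Compound 1 stands at 36600 nM, a weak inhibitor by any ordinary standard. Compound 2 stands not at a number but at a limit of the measurement, > 40000 nM; the assay reported only that limit and nothing more precise, which is the situation described by the limit of > 40000 nM in this assay, at which 1 of the 2 values shown sits. Because compound 2 sits at that limit, nothing can be said about how it compares with compound 1 beyond the fact that neither is potent.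

Compound 3, `CC1=CCc2c(O)cc(CCc3ccccc3O)cc2OC1`, has not yet been measured in this assay . It differs from compound 2 in a single place: hydroxy in place of hydrogen on an aromatic carbon. Among the measured compounds shown here, no step between two measured compounds is available here to show how such a change usually plays out, so the expectation rests on the weakness of compound 2 alone. The step from compound 2 to compound 3 in this assay is expected to be small, a number no higher from compound 2 to compound 3 (the limit leaves the size open), within the usual scatter rather than beyond it. Compound 3 is therefore estimated at 40000 nM, with a plausible range from 15000 nM to 100000 nM, and a good chance that the assay again reports only a limit.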

Compound 3, half-maximal inhibitory concentration: 28900 nM
Estimate against measurement, compound 3: 1.4-fold (0.14 log units) above; the range from low to high includes it.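

The change from phenyl to 2-hydroxyphenyl is the first variation shown on this aromatic ring, which is unsubstituted in the two earlier compounds, and in this assay it gives an at least 1.3-fold lower number from compound 2 to compound 3 (0.14 log units; that floor lies within the scatter). With the hydroxy group in this place, ortho to a large group, compound 3 gives a measured number, 28900 nM, which is still weak by any ordinary standard. The result therefore shows that this position accepts a hydroxy group without any loss that the assay can detect, but the true size of the step stays unknown, because compound 2 has only a limit and no number of its own: the limit of > 40000 nM in this assay, at which 1 of the 3 values shown sits.

The compounds shown leave open whether a methoxy group, an amine or a fluorine atom in the same place would give a similar number, and whether a hydroxy group elsewhere on this ring would do the same. They also leave open whether the same hydroxy group would change the number of compound 1, whose core is different, so the finding stays confined to this one pair.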